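From naphthalen-2-yl to 4-methoxyphenyl: an expected limit

The source may hold more compounds than are shown below. What is called first, only, known or untested is meant among the compounds shown, and "the series" means these compounds.

Compound 2 `O=C(O)C1=Cc2ccccc2OC1(OCc1cc(-c2ccc3ccccc3c2)no1)C(F)(F)F` carries a naphthalen-2-yl group on the five-membered aromatic ring with 1 nitrogen and 1 oxygen. In a functional assay on A549 cells (Homo sapiens) for inhibition, read by MTT assay, with a stated time of 24 h (a lower number here means a stronger inhibitor, a higher number a weaker inhibitor), compound 2 reaches only the limit of the assay, > 150000 nM, so no number is known for it. Its ethyl ester, compound 1 `CCOC(=O)C1=Cc2ccccc2OC1(OCc1cc(-c2ccc3ccccc3c2)no1)C(F)(F)F`, likewise gives only the limit > 150000 nM in this assay. The step that the two limits leave unreadable from compound 1 to compound 2 therefore cannot be read, since both values sit at the limit of > 150000 nM in this assay, at which 2 of the 3 values shown sit. Among the compounds with values here, a third compound, compound 3 `CCOC(=O)C1=Cc2ccccc2OC1(OCc1cn(CC(=O)Nc2ccccc2F)nn1)C(F)(F)F`, built on the shared core but with a different group on the linking ring, gives 50100 nM in this assay; it differs from compound 2 in more than one place, so no single step connects the two.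

Compound 4 `COc1ccc(-c2cc(COC3(C(F)(F)F)Oc4ccccc4C=C3C(=O)O)on2)cc1` differs from compound 2 by 4-methoxyphenyl in place of naphthalen-2-yl on an aromatic carbon. Within the data shown here, no measured step bears on this change: the only step recorded, from the ester to the acid, is unreadable, and the remaining compound is not one step away. The account thus starts from a limit, and compound 4 is expected to stay near it, with the step that the limit leaves unreadable from compound 2 to compound 4 expected to lie within the scatter. Compound 4 is estimated at 200000 nM in this assay, within 60000 nM to 600000 nM, and most likely reported again only as a limit.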

Compound 4, half-maximal inhibitory concentration: 36200 nM
Compound 4: the middle estimate sits 5.5-fold (0.74 log units) above what was measured; measured number below the stated range.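

The aromatic carbon next to the ring nitrogen proves to be a place where a change of group can move the read-out: in this assay, 4-methoxyphenyl in place of naphthalen-2-yl gives an at least 4.1-fold lower number from compound 2 to compound 4 (0.61 log units; beyond the scatter). This is the first readable step among the compounds shown, and with compound 4 at 36200 nM, a carboxylic acid on the shared core now has a measured number in this assay. The true size of the step may be larger, and only its minimum can be stated, because compound 2 is known only as a limit: the limit of > 150000 nM in this assay, at which 2 of the 4 values shown sit.

The change replaces two aromatic rings with one and also brings in a methoxy group, so these compounds do not tell which of the two goes with the lower number; a plain phenyl group or a 4-hydroxyphenyl group at this position would bear on that question. The ethyl ester of compound 4 is also absent from the compounds shown, and the effect of going from ester to acid on this aryl group remains open.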